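The source may hold more compounds than are shown below. What is called first, only, known or untested is meant among the compounds shown, and "the series" means these compounds.

Compound 1 `O=C(NCc1ccc(CNS(=O)(=O)c2ccccc2)cc1)c1cccc(F)c1` is the starting point. In an assay on MDA-MB-231 cells for binding affinity to C-X-C chemokine receptor type 4 (Homo sapiens), read by immunofluorescence and microscopy, with stated times of 10 min and 30 min (on this read-out higher numbers stand for an effect only at larger amounts of compound and lower numbers for an effect already at smaller amounts), compound 1 gives 100 nM, the same number at the digits shown as compound 2 `Cc1ccc(S(=O)(=O)NCc2ccc(CNC(=O)c3cccc(Cl)c3)cc2)cc1`, which gives 100 nM; together these are the highest of the three values, while compound 3 `Cc1ccc(S(=O)(=O)NCc2ccc(CNC(=O)c3ccncc3)cc2)cc1` gives 10 nM. Among the compounds with values here, the only single-point step among them is a 10-fold lower number from compound 2 to compound 3 (1.00 log units; beyond the scatter).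

Compound 4 `O=C(NCc1ccc(CNS(=O)(=O)c2ccccc2)cc1)c1c(Cl)cc(Cl)cc1Cl` differs from compound 1 in one place: 2,4,6-trichlorophenyl in place of 3-fluorophenyl on a carbonyl carbon. Within the data shown here, no measured step exchanges one halogen-bearing phenyl for another, so a 10-fold lower number from compound 2 to compound 3 (1.00 log units; beyond the scatter) does not bear directly on this change, and no step beyond the scatter is expected; the estimated step is no change at the digits printed from compound 1 to compound 4 (within the scatter). Compound 4 is expected to give about 100 nM, within a range from 30 nM to 300 nM.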

Compound 4, effective concentration (reported as EC, without a stated level of effect): 10 nM
Compound 4: middle estimate off by 10-fold (1.00 log units), on the high side, and the stated range ends above it.
By their numbers in this assay, from the lowest: compounds 3 and 4 (each within the scatter of the next); then compounds 1 and 2 (each within the scatter of the next).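

The step of a 10-fold lower number from compound 1 to compound 4 (1.00 log units; beyond the scatter) shows that in this assay the number can move at this place on the carbonyl carbon even with a carbon-only aromatic ring kept there. Within the data shown here, until now, the only step at this place was the exchange of a phenyl ring for pyridin-4-yl, so a change of ring type was not needed for a step of this size. Nothing at hand explains the drop in the number.

As far as these compounds go, how much each of the three chlorines contributes remains open. So does what a methoxy group or an amine on this phenyl ring would do.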